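This account rests on a few compounds, and the source may have more. Where it says the series, first, only, none or still open, it means among the compounds named here.

Measured so far in an assay on H285R cells for inhibition of cytochrome P450 11B2, mitochondrial (Homo sapiens), read by immunoassay, with a stated time of 24 h; a lower number here means a stronger inhibitor, a higher number a weaker inhibitor:
compound 1 `Cc1c(-c2cccnc2)n(C)c2ccccc12`, 9 nM
compound 2 `Cn1c(-c2cccnc2)c(C#N)c2ccc(Cl)cc21`, 4 nM
compound 3 `CN(C)S(=O)(=O)Oc1cncc(-c2c(C#N)c3ccccc3n2C)c1`, 39 nM

Compound 3 carries the highest of the three numbers in this assay; compound 1 sits closest, with a lower number by a margin beyond the scatter, and compound 2 lies furthest, lower still and also beyond the scatter. Among the measured compounds shown here, no single-change step between measured compounds exists, so the size of any exchange has to be judged from the spread alone.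

Compound 4 `CCS(=O)(=O)Nc1cncc(-c2c(C#N)c3ccccc3n2C)c1` differs from compound 3 by (ethylsulfonyl)amino in place of (dimethylsulfamoyl)oxy on an aromatic carbon, two atoms from the ring nitrogen. For the measured compounds named here, no measured pair shows what such an exchange does in this assay. The expectation is a small step toward a lower number, most likely within the scatter, a 1.6-fold lower number from compound 3 to compound 4 (0.19 log units; within the scatter). Compound 4 is estimated at 25 nM, with a range from 7 nM to 90 nM.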

Compound 4, half-maximal inhibitory concentration: 380 nM
Compound 4: the middle estimate sits 15-fold (1.18 log units) below what was measured; measured number above the stated range.
By their numbers in this assay, from the lowest: compound 2; then compound 1; then compound 3; then compound 4.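

In this assay, this position on the aromatic ring is sensitive to the group it carries: (ethylsulfonyl)amino in place of (dimethylsulfamoyl)oxy, two atoms from the ring nitrogen, gives a 9.7-fold higher number from compound 3 to compound 4 (0.99 log units; beyond the scatter). Among the compounds shown here, the change is the first single-place comparison, and it shows that these two sulfur-bearing groups are not interchangeable here, although the entering group differs by one hydrogen-bond donor. Nothing available accounts for this step. Which part of the exchange carries the step stays open, as does the reading of a plain amine or a carboxylic acid at this carbon.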